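Changing the side group on a thiazole amine while watching cytotoxicity

The source may report more compounds than this note shows. Statements on the series, on what has been measured and on what is new or still open speak of the compounds shown alone.

Three compounds of this series have been examined in an ADME assay on HepG2 2.2.15 cells (Homo sapiens) for cytotoxicity; a lower number here means that less compound is tolerated, a higher number that more compound is tolerated. Compound 1, `O=C(Nc1ncc(Cc2ccc(F)cc2)s1)C1CCCCC1`, gives a limit of the assay rather than a number, > 50000 nM. Compound 2, `O=C(Nc1ncc(Cc2ccc(Cl)cc2)s1)c1cccs1`, also gives only a limit, > 50000 nM. Compound 3, `CCCCC(CC)CNc1ncc(C(Oc2ccc3cc(Br)ccc3c2)c2ccc(Cl)cc2)s1`, is recorded in this assay simply as "not toxic" (no number reported), without any number. Compound 3 therefore cannot be placed at a definite point; what is known is that it sits alongside (the limit of > 50000 nM in this assay, at which 2 of the 3 values shown sit), the level at which the other two compounds also stand.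

Compound 4, `Cc1noc(C)c1C(=O)Nc1ncc(C(Oc2ccc3cc(Br)ccc3c2)c2ccc(Cl)cc2)s1`, has not yet been measured. It is compound 3 with one change, ((3,5-dimethyl-1,2-oxazol-4-yl)carbonyl in place of 2-ethylhexyl on a nitrogen on an aromatic ring). Among the compounds with values here, no step between two measured compounds exists for this change, so its effect on this assay can only be expected, not read off. Since every value gathered here lies at or beyond the limit of the assay, the expectation is that the change brings no shift beyond the usual scatter and that compound 4 likewise proves tolerated up to the highest concentration tested. The estimate for compound 4 in this assay is 50000 nM, with a range from 20000 nM to 100000 nM.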

Compound 4, half-maximal cytotoxic concentration: "not toxic" (no number reported)
Compound 4 has no reported number here, and the estimate cannot be compared.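

Within the data shown here, compound 3 and compound 4 are both recorded only as "not toxic" in this assay, so no step between them can be read. The compounds shown leave open at what concentration any of them harms these cells, and whether swapping the side group matters, because the data hold no definite number, only a limit: the limit of > 50000 nM in this assay, at which 2 of the 4 values shown sit.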